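One group exchanged between compound 2 and compound 3

The source may hold more compounds than are shown below. What is called first, only, known or untested is meant among the compounds shown, and "the series" means these compounds.

Of the compounds shown here, two have so far been read in a physicochemical assay for lipophilicity, using the shake flask method, in phosphate buffer, measured as octanol-water partition, with a stated time of 30 min, at pH 7.4 (on this read-out higher numbers stand for higher lipophilicity and lower numbers for lower lipophilicity), and they sit level. Compound 1 (`CN(c1ncco1)c1cnc(NCc2c(F)ccc3c2CCO3)n2cnnc12`) gives 2.1 and compound 2 (`Cc1nc(CN(C)C)ccc1-c1cnc(NCc2c(F)ccc3c2CCO3)c2cn[nH]c(=O)c12`) gives 2 on this scale, which places the two within the usual scatter of each other.

Compound 3 (`Cc1nn(C)cc1-c1cnc(NCc2c(F)ccc3c2CCO3)c2cn[nH]c(=O)c12`) has not yet been measured. It differs from compound 2 in one place, with 1,3-dimethyl-1H-pyrazol-4-yl in place of 6-((dimethylamino)methyl)-2-methylpyridin-3-yl on an aromatic carbon. Among the compounds with values here, compound 1 and compound 2 differ in more than one place, so no measured step shows what such an exchange does.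

In this assay a small rise is expected, close to the edge of the scatter, and a result with no change beyond the scatter would be unsurprising. The size expected is a number 0.30 log units higher from compound 2 to compound 3 (within the scatter) and it remains only an estimate. Within the data shown here, the sole anchor is compound 2 at 2 on this scale, together with the structural change. Compound 3 is therefore expected at 2.3 within a range from 1.8 to 2.8 once it is measured.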

Compound 3, distribution coefficient: 2.8
Compound 3: the middle estimate sits 0.50 log units below what was measured, within the range that was stated.
By their numbers in this assay, from the lowest: compounds 2 and 1 (each within the scatter of the next); then compound 3.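

Within the data shown here, this is the first step read at this position, on an aromatic carbon of the six-membered aromatic ring with 1 nitrogen, which compound 1 and compound 2 could not provide because they differ in more than one place. In this assay, 1,3-dimethyl-1H-pyrazol-4-yl in place of 6-((dimethylamino)methyl)-2-methylpyridin-3-yl gives a number 0.80 log units higher from compound 2 to compound 3 (beyond the scatter), so the read-out does respond to the group at this position, and here it rises as the group goes from 11 heavy atoms to 7, with no net charge on either group as counted. Nothing measured here accounts for the size of this step.

The exchange alters the ring and its substituents together, so these compounds do not separate the change of ring from the loss of the (dimethylamino)methyl chain. From the compounds shown here alone, what a plain 2-methylpyridin-3-yl would read at this position remains open, as does whether a pyrazole carrying a carboxylic acid would follow compound 3, and whether the step holds on any other core.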